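A Sulfonyl for a Carbamate on the Chain End

The source may hold more compounds than are shown below. What is called first, only, known or untested is meant among the compounds shown, and "the series" means these compounds.

Measured compounds:
- compound 1 `CC(C)(C)OC(=O)NCCCCNC(=O)CN1CN(c2ccccc2)C2(CCN(C(=O)c3ccc(C4CCCCC4)cc3)CC2)C1=O`, 4600 nM
- compound 2 `CC(C)(C)OC(=O)NCCCCNC(=O)CN1CN(c2ccccc2)C2(CCN(C(=O)c3ccc(C(C)(C)C)cc3)CC2)C1=O`, "not determined" (no result reported)
- compound 3 `CC(C)(C)OC(=O)N1CCN(C(=O)CN2CN(c3ccccc3)C3(CCN(C(=O)c4ccc(C5CCCCC5)cc4)CC3)C2=O)CC1`, 3500 nM

The read-out throughout is an assay on HEK293 cells for displacement of a labelled ligand from NPC1-like intracellular cholesterol transporter 1 (Homo sapiens); a higher number here means a weaker inhibitor, a lower number a stronger inhibitor. In this assay compound 1 gives 4600 nM, and compound 3 gives 3500 nM; these two numbers sit within the usual scatter of each other, so neither can be called the stronger inhibitor. Compound 2 shares the core of these compounds but carries a tert-butyl group where compound 1 carries a cyclohexyl group, and for compound 2 this assay reports "not determined" (no result reported), so it cannot be placed among the measured compounds.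

Compound 4 `CC(C)(C)c1ccc(C(=O)N2CCC3(CC2)C(=O)N(CC(=O)NCCCCNS(C)(=O)=O)CN3c2ccccc2)cc1` follows from compound 2 by a single change at the chain end: methylsulfonyl in place of tert-butoxycarbonyl on an amine nitrogen. Both groups that leave and enter carry two hydrogen-bond acceptors and no donor, and neither brings a ring or a charge.

Among the measured compounds shown here, with no measured step of this kind available, the expectation rests on the level at which compounds 1 and 3 sit. Compound 4 is expected to give about 4000 nM in this assay, with a plausible range from 1500 nM to 12000 nM, and no shift beyond the scatter is anticipated in either direction.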

Compound 4, half-maximal inhibitory concentration: 4500 nM
Estimate against measurement, compound 4: 1.1-fold (0.05 log units) below; the range from low to high includes it.
By their numbers in this assay, from the lowest: compounds 3, 4 and 1 (each within the scatter of the next).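

Compound 2 has no number in this assay, so the change to compound 4, which gives 4500 nM, cannot be read as a step. As far as these compounds go, whether methylsulfonyl in place of tert-butoxycarbonyl on the chain end shifts the result at all stays open. No data shown here bear on the level of compound 4.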